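From methoxycarbonyl to amino on compound 2

The source may hold more compounds than are shown below. What is called first, only, known or untested is meant among the compounds shown, and "the series" means these compounds.

Of the compounds shown here, three have so far been read in a functional assay on HCT-116 cells (Homo sapiens) for inhibition, read by MTT assay, with a stated time of 48 h (a higher number here means a weaker inhibitor, a lower number a stronger inhibitor), and they spread widely. Compound 1 (`C/C=C/C(=O)N(Cc1cc(OC)c(OC)c(OC)c1)c1ccc(OC)c(O)c1`) gives 8450 nM in that test, compound 3 (`COc1ccc(CN(C(=O)CN=[N+]=[N-])c2cc(OC)c(OC)c(OC)c2)cc1O`) gives 410 nM there, and compound 2 (`COC(=O)c1cc(CNc2cc(OC)c(OC)c(OC)c2)ccc1OC`) gives 38100 nM as the highest number of the three. Compound 2 is thus the weakest inhibitor of the set, and its gaps to both others lie beyond the scatter of repeated measurements. These three differ in more than one place, so no single change can be read from them.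

Compound 4 (`COc1ccc(CNc2cc(OC)c(OC)c(OC)c2)cc1N`) has not yet been measured. It carries amino in place of methoxycarbonyl on an aromatic carbon, ortho to a methoxy group and meta to a large group, and the change counts as amino in place of methoxycarbonyl on an aromatic carbon with the rest of compound 2 kept. Going by the values given here, no measured pair shows this swap, so the expectation is loose and rests only on compound 2 at 38100 nM lying above the other two. The expected change is a 9.5-fold lower number from compound 2 to compound 4 (0.98 log units; beyond the scatter) toward a stronger inhibitor, beyond the scatter. Compound 4 is estimated at 4000 nM in this assay with an expected range from 600 nM to 25000 nM until it is tested.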

Compound 4, half-maximal inhibitory concentration: 8270 nM
The estimate for compound 4 lay 2.1-fold (0.32 log units) below the measured number; measured number inside the range.
By their numbers in this assay, from the lowest: compound 3; then compounds 4 and 1 (each within the scatter of the next); then compound 2.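

In this assay, the aromatic carbon ortho to a methoxy group and meta to a large group now has its first direct reading: with the rest of the structure kept, amino in place of methoxycarbonyl gives a 4.6-fold lower number from compound 2 to compound 4 (0.66 log units; beyond the scatter), a modest step toward a stronger inhibitor. Going by these compounds alone, the number at this position therefore depends on the group it carries, as the earlier compounds, which differ in more than one place, could not show. The group leaving has 4 heavy atoms, with 2 hydrogen-bond acceptors and no donor, while the group entering has 1 heavy atom, with 1 hydrogen-bond donor and 1 hydrogen-bond acceptor, and nothing available explains why the number moves with this change.

This single pair cannot separate what is lost with the methoxycarbonyl from what is gained with the amino. On these data alone, it remains open whether a carboxylic acid, an acetamide or a longer aminomethyl chain on this carbon would take the number further in the same direction or return it toward that of the methoxycarbonyl.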